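Chain extension on the butylsulfanyl arm of compound 2

This account rests on a few compounds, and the source may have more. Where it says the series, first, only, none or still open, it means among the compounds named here.

Compound 1 `CCCCN(C)c1nc(C(C)(C)C)ccc1CNC(=O)C(C)c1ccc(NS(C)(=O)=O)c(F)c1`: in an assay on cells for antagonist activity at transient receptor potential cation channel subfamily V member 1 (Homo sapiens), read by FLIPR and calcium flux, with a stated time of 6 min (a lower number here means a stronger inhibitor, a higher number a weaker inhibitor), compound 1 gives 1.2 nM.
Compound 2 `CCCCSc1nc(C(C)(C)C)ccc1CNC(=O)C(C)c1ccc(NS(C)(=O)=O)c(F)c1`: in this assay compound 2 gives 3.2 nM.

Compound 2 stands with the highest of the two numbers so far; the only shown step is a 2.7-fold higher number from compound 1 to compound 2 (0.43 log units; beyond the scatter). Compound 3 `CCCCCSc1nc(C(C)(C)C)ccc1CNC(=O)C(C)c1ccc(NS(C)(=O)=O)c(F)c1` differs from compound 2 by methyl in place of hydrogen on a saturated chain carbon, four bonds along the chain from a sulfur. For the measured compounds named here, no measured step probes chain length on this arm, so the step from compound 1 to compound 2 gives no direct guide; adding one carbon to an open chain usually moves numbers little. A step within the scatter is therefore expected, a 1.1-fold higher number from compound 2 to compound 3 (0.04 log units; within the scatter). Compound 3 is estimated at 3.5 nM, range 1.2 nM to 10 nM.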

Compound 3, inhibition constant: 3.1 nM
Compound 3: the middle estimate sits 1.1-fold (0.05 log units) above what was measured; low and high end bracket the measured number.
By their numbers in this assay, from the lowest: compound 1; then compounds 3 and 2 (each within the scatter of the next).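

In this assay, pentylsulfanyl in place of butylsulfanyl gives a 1.0-fold lower number from compound 2 to compound 3 (0.01 log units; within the scatter), so on this arm the added methyl, four bonds along the chain from the sulfur, leaves the number within the scatter. With the longer chain, the gap to the butyl(methyl)amino arm remains: a 2.6-fold higher number from compound 1 to compound 3 (0.41 log units; beyond the scatter), beyond the scatter but modest. No other data bear on this result.

From the compounds shown here alone, whether the number stays flat with a hexyl or branched chain remains open. So does the effect of a terminal hydroxyl or amine on the pentyl arm.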